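The source may hold more compounds than are shown below. What is called first, only, known or untested is meant among the compounds shown, and "the series" means these compounds.

Measured in a physicochemical assay for solubility, at pH 7.4; on this read-out lower numbers stand for lower solubility and higher numbers for higher solubility:
- compound 1 `O=C(CC(c1ccccc1)c1ccccc1)N1CCN(C(c2ccccc2)c2cccc(Cl)c2)CC1`: 0.37 ug/mL
- compound 2 `CN1CCC(CN2CCN(C(=O)CC(c3ccccc3)c3ccccc3)CC2)CC1`: 151 ug/mL

Compound 1 holds the lower of these two numbers, and the gap up to compound 2 lies well beyond the scatter. Compound 3 `O=C(CC(c1ccccc1)c1ccccc1)N1CCN(C(c2ccccc2)c2cccc(C(F)(F)F)c2)CC1` keeps the core of compound 1 and swaps a single group: trifluoromethyl in place of chloro on an aromatic carbon. In words, trifluoromethyl takes the place of chloro on an aromatic carbon. Going by the values given here, no measured pair shows this exchange, so the expectation is tentative: a small drop in this assay, perhaps none beyond the scatter. The estimated step of a 1.5-fold lower number from compound 1 to compound 3 (0.17 log units; within the scatter) is modest. Compound 3 is expected at 0.25 ug/mL, within an estimated range of 0.08 ug/mL to 0.8 ug/mL.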

Compound 3, solubility: 0.14 ug/mL
For compound 3 the middle estimate is 1.8-fold (0.25 log units) above the measured one; the range from low to high includes it.
By their numbers in this assay, from the lowest: compound 3; then compound 1; then compound 2.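

Going by these compounds alone, this is the first reading of any change at this position: in this assay trifluoromethyl in place of chloro on this aromatic carbon gives a 2.6-fold lower number from compound 1 to compound 3 (0.42 log units; beyond the scatter) and so takes an already low number further down. A small exchange at this one place can therefore move the read-out beyond the scatter. No measurement at hand says why the number moves. Only this one exchange is shown here, so it remains open whether an amine or a carboxylic acid on the same aromatic carbon would raise the number, and by how much.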